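From benzyloxycarbonyl to methyl on a sulfur

The source may hold more compounds than are shown below. What is called first, only, known or untested is meant among the compounds shown, and "the series" means these compounds.

Among the measured compounds shown here, in a functional assay on HCT-116 cells (Homo sapiens) for inhibition, read by MTT assay, with a stated time of 96 h (a higher number here means a weaker inhibitor of growth, a lower number a stronger inhibitor of growth), compound 1 `O=C(OCc1ccccc1)SCCCCCCNC(=O)c1cc(-c2ccncc2)n[nH]1` gives 18200 nM, the one true number among the three compounds measured. Compound 2 `O=C(NCCCCCCS)c1cc(-c2ccc3ccccc3c2)n[nH]1` gives only a limit of the assay, > 50000 nM. Compound 3 `O=C(NCCCCCCS)c1cc(-c2cnccn2)n[nH]1` also gives only a limit, > 50000 nM. Compound 4 `CSCCCCCCNC(=O)c1cc(-c2ccncc2)n[nH]1` is still unmeasured and carries methyl in place of benzyloxycarbonyl on a sulfur. For the measured compounds named here, no measured step speaks directly to this change, so any forecast is loose. Compound 1 is already a weak inhibitor at 18200 nM. A moderate shift toward weaker growth inhibition is expected in this assay, with a result at the limit quite possible. The estimated step is a 2.2-fold higher number from compound 1 to compound 4 (0.34 log units; beyond the scatter). Compound 4 is estimated at 40000 nM, with an expected range from 15000 nM to 90000 nM.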

Compound 4, concentration for 50% growth inhibition: > 50000 nM
Compound 4: a limit, no number (the forecaster's own chance of this, stated with the estimate: 60%); middle value at least 1.2-fold (0.09 log units) from the limit.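

Compound 4 gives only a limit of the assay, > 50000 nM. In this assay, among the compounds shown here, methyl in place of benzyloxycarbonyl on a sulfur gives an at least 2.7-fold higher number from compound 1 to compound 4 (0.43 log units; beyond the scatter), the first step that can be read at this position, and it shows that the measurable growth inhibition of compound 1 is lost with this change. The full size of the step stays unknown because the reading stops at the limit: the limit of > 50000 nM in this assay, at which 3 of the 4 values shown sit.

As far as these compounds go, whether an acetyl or a benzyl group on this sulfur would keep the number of compound 1 stays open. So does which part of benzyloxycarbonyl the measurable inhibition depends on.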